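Carboxyfuran for methylpyrazole on a potent core

This account rests on a few compounds, and the source may have more. Where it says the series, first, only, none or still open, it means among the compounds named here.

Among the measured compounds shown here, in an assay on isolated protein for inhibition of ubiquitin carboxyl-terminal hydrolase 7 (Homo sapiens), with stated times of 30 min and 2 h (a lower number here means a stronger inhibitor, a higher number a weaker inhibitor), compound 1, `Cn1cc(-c2ccc(CN3CCC(O)(Cn4cnc5c(-c6ccc(CN)cc6)n(C)nc5c4=O)CC3)c(Cl)c2)cn1`, gives 291 nM, the higher of the two numbers measured so far. Compound 2, `CC(=O)NCc1ccc(-c2c3ncn(CC4(O)CCN(Cc5ccc(-c6ccco6)cc5Cl)CC4)c(=O)c3nn2C)cc1`, gives 46.1 nM in this assay, a lower number than compound 1 by a margin beyond the usual scatter. Compound 3, `Cn1nc2c(=O)n(CC3(O)CCN(Cc4ccc(-c5ccc(C(=O)O)o5)cc4Cl)CC3)cnc2c1-c1ccc(CN)cc1`, has not yet been measured; it carries the change (5-carboxyfuran-2-yl in place of 1-methyl-1H-pyrazol-4-yl on an aromatic carbon). For the measured compounds named here, no measured pair isolates this change, so only a modest step is expected from compound 1 to compound 3 in this assay, a 1.9-fold lower number from compound 1 to compound 3 (0.29 log units; within the scatter), toward a lower number. Compound 3 is therefore estimated at 150 nM, within 50 nM to 450 nM.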

Compound 3, half-maximal inhibitory concentration: 753 nM
Compound 3: middle estimate off by 5.0-fold (0.70 log units), on the low side; measured number above the stated range.
By their numbers in this assay, from the lowest: compound 2; then compound 1; then compound 3.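

In this assay, 5-carboxyfuran-2-yl in place of 1-methyl-1H-pyrazol-4-yl on the aromatic carbon meta to the chloro group gives a 2.6-fold higher number from compound 1 to compound 3 (0.41 log units; beyond the scatter) and so shows that the number responds to what this position carries, though the step remains modest. No available evidence accounts for this step. Compound 2 differs from compound 3 in more than one place, so the furan ring and its carboxylic acid cannot be separated here. On these data alone, whether a methyl ester or primary amide in place of that acid would shift the number remains open.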